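The compounds below may be only part of what the source reports. "The series", "measured", "known", "first", "only" and "open" are said of these compounds alone.

In a functional assay on MCF7 cells (Homo sapiens) for inhibition, read by MTT assay, with stated times of 18 h and 4 h (on this read-out lower numbers stand for stronger inhibition and higher numbers for weaker inhibition), the measured compounds read as follows:

Compound 1 `CCCCCCCCCCOP(=O)(O)OCCSC(=S)N1CCCC1` gives 70000 nM
Compound 2 `CCCCCCCCCCOP(=O)(O)OCCSC(=S)N1CCN(C)CC1` gives 99600 nM
Compound 3 `CCCCCCCCCCOP(=O)(O)OCCSC(=S)N1CCCCC1` gives 7240 nM

Compound 2 sits with compound 1 at the high end of these numbers (a 1.4-fold higher number from compound 1 to compound 2 (0.15 log units; within the scatter)), while compound 3 lies well away from it (a 14-fold lower number from compound 2 to compound 3 (1.14 log units; beyond the scatter)). Compound 4 `CCCCCCOP(=O)(O)OCCSC(=S)N1CCN(C)CC1` keeps the 4-methylpiperazin-1-yl group of compound 2 and changes only the chain, with hydrogen in place of butyl on a saturated chain carbon (hydrogen in place of butyl on a saturated chain carbon, six bonds along the chain from an oxygen on an unsaturated carbon).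

For the measured compounds named here, none of the measured steps touches this chain. All three replace the group on the thiocarbonyl carbon, so they bear on the change only indirectly. They show that a single change in this series can stay within the scatter (a 1.4-fold higher number from compound 1 to compound 2 (0.15 log units; within the scatter)) or reach a modest size (a 9.7-fold lower number from compound 1 to compound 3 (0.99 log units; beyond the scatter)). No measured compound carries a different chain, so the direction is a judgement and not a shown trend. A small move toward a higher number is expected in this assay (a 1.6-fold higher number from compound 2 to compound 4 (0.21 log units; within the scatter)), and no real change remains possible. Compound 4 is estimated at 160000 nM (expected range 60000 nM to 450000 nM).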

Compound 4, half-maximal inhibitory concentration: 58000 nM
For compound 4 the middle estimate is 2.8-fold (0.44 log units) above the measured one; measured number outside the range, below it.
By their numbers in this assay, from the lowest: compound 3; then compounds 4, 1 and 2 (each within the scatter of the next).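

In this assay, for the compounds shown here, the first measured change to the chain, hydrogen in place of butyl on a saturated chain carbon, gives a 1.7-fold lower number from compound 2 to compound 4 (0.23 log units; within the scatter). With the 4-methylpiperazin-1-yl group held in place, removing butyl at this position therefore produces no real difference in this assay, so the chain change joins the swap of pyrrolidin-1-yl for 4-methylpiperazin-1-yl as a step that stays within the scatter, whereas the group on the thiocarbonyl carbon can produce a much larger step, as in a 14-fold lower number from compound 2 to compound 3 (1.14 log units; beyond the scatter). Nothing available explains why the butyl group can be replaced by hydrogen here without a real difference in the read-out.

The compounds shown leave open whether the same replacement of butyl by hydrogen would also stay within the scatter alongside the piperidin-1-yl group of compound 3, the one group here whose steps to the other two lie beyond the scatter. They also leave open how the assay would read with a longer chain at this position, or with a chain ending in an amine or a carboxylic acid.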